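Swapping the nitrophenyl of compound 2 for a dimethoxyphenyl

This account rests on a few compounds, and the source may have more. Where it says the series, first, only, none or still open, it means among the compounds named here.

Compound 1 `CSc1nc(NCCCNc2ccnc3cc(Cl)ccc23)c(C#N)c(-c2ccccc2)n1` gives 100000 nM in an ADME assay on Vero cells (Chlorocebus sabaeus) for cytotoxicity, read by microscopy; a lower number here means that less compound is tolerated, a higher number that more compound is tolerated. Compound 2 `CSc1nc(NCCCCNc2ccnc3cc(Cl)ccc23)c(C#N)c(-c2cccc([N+](=O)[O-])c2)n1` gives 20000 nM. Compound 3 `CSc1nc(-c2ccc([N+](=O)[O-])cc2)c(C#N)c(N2CCN(c3ccnc4cc(Cl)ccc34)CC2)n1` gives 100000 nM.

Compound 2 thus stands lowest of the three, with compound 1 and compound 3 both at numbers beyond the scatter above it. Compound 4 `COc1ccc(-c2nc(SC)nc(NCCCCNc3ccnc4cc(Cl)ccc34)c2C#N)cc1OC` has not yet been measured in this assay. It differs from compound 2 in one place: 3,4-dimethoxyphenyl in place of 3-nitrophenyl on an aromatic carbon. For the measured compounds named here, no step between measured compounds matches this change, so its effect must be guessed. Compound 1 and compound 3 suggest that the higher number is the common outcome in this series, and a moderate rise is expected, as the step of a 2.5-fold higher number from compound 2 to compound 4 (0.40 log units; beyond the scatter) shows. Compound 4 is therefore estimated at 50000 nM, within 20000 nM to 100000 nM.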

Compound 4, minimum cytotoxic concentration: > 100000 nM
Compound 4: a limit, no number; the forecaster's own chance of this, stated with the estimate: 20%; middle value at least 2.0-fold (0.30 log units) away from the limit.
By their numbers in this assay, from the lowest: compound 2; then compounds 1 and 3 (each within the scatter of the next).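

Exchanging 3-nitrophenyl for 3,4-dimethoxyphenyl on this aromatic carbon, with the rest of compound 2 unchanged, gives an at least 5.0-fold higher number from compound 2 to compound 4 (0.69 log units; beyond the scatter) in this assay. This is the only one-place step shown, and it ties the low number of compound 2 to the aryl group at this place. For compound 4 the reading is a limit and not a number, so the step is only a lower bound: the limit of > 100000 nM in this assay, at which 1 of the 4 values shown sits.

As far as these compounds go, whether losing the nitro group or gaining the methoxy groups drives the step remains open. A phenyl ring carrying a single methoxy group or an amine at this place would help to separate the two.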